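Swapping the Arylamino Group for Piperidinyl on the Shared Core

The source may report more compounds than this note shows. Statements on the series, on what has been measured and on what is new or still open speak of the compounds shown alone.

Compound 1, `O=C1C(Nc2cccc(Cl)c2)=CC(=O)c2c1nc1n2[C@H]2OC[C@@H](O)[C@H]2OC1`: 3080 nM in a functional assay on ECa-109 cells for inhibition, with ECa-109 cell line (Homo sapiens) as the target, read by sulforhodamine B assay; a lower number here means a stronger inhibitor, a higher number a weaker inhibitor
Compound 2, `Cc1ccc(NC2=CC(=O)c3c(nc4n3[C@H]3OC[C@@H](O)[C@H]3OC4)C2=O)cc1C`: 4090 nM in this assay
Compound 3, `COc1ccc(NC2=CC(=O)c3c(nc4n3[C@H]3OC[C@@H](O)[C@H]3OC4)C2=O)cc1`: 3410 nM in this assay

Compound 3 stands second highest of these three numbers, yet all three lie within the scatter of one another: the steps of a 1.1-fold higher number from compound 1 to compound 3 (0.04 log units; within the scatter) and a 1.2-fold lower number from compound 2 to compound 3 (0.08 log units; within the scatter) are both within the scatter, as is a 1.3-fold higher number from compound 1 to compound 2 (0.12 log units; within the scatter). Compound 4, `O=C1C(N2CCCCC2)=CC(=O)c2c1nc1n2[C@H]2OC[C@@H](O)[C@H]2OC1`, differs from compound 3 in one place: piperidin-1-yl in place of (4-methoxyphenyl)amino on a double-bonded ring carbon. Each measured step exchanges one substituted phenyl for another on the amine nitrogen, and none removes the aromatic ring or the hydrogen-bond donor, so none bears directly on this change. What the measured steps do show is that varying the group on that carbon has so far left the number unchanged beyond the scatter. Within the data shown here, the expectation for compound 4 is therefore a step of a 1.2-fold higher number from compound 3 to compound 4 (0.07 log units; within the scatter), with a wide range because no measured step tests a saturated ring in this place. Compound 4 is estimated at 4000 nM, between 1200 nM and 14000 nM.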

Compound 4, half-maximal inhibitory concentration: > 8000 nM
Compound 4: no number, only a limit; the forecaster's own chance of this, stated with the estimate: 10%; at least 2.0-fold (0.30 log units) between middle value and limit.
By their numbers in this assay, from the lowest: compounds 1, 3 and 2 (each within the scatter of the next). At a limit, above all of these: compound 4.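

Compound 4 has no number, only a limit: the limit of > 8000 nM in this assay, at which 1 of the 4 values shown sits.

Piperidin-1-yl in place of an arylamino group on the double-bonded ring carbon gives an at least 2.3-fold higher number from compound 3 to compound 4 (0.37 log units; beyond the scatter) and an at least 2.5-fold higher number from compound 1 to compound 4 (0.41 log units; beyond the scatter), while the comparison with the third arylamino compound gives an at least 1.9-fold higher number from compound 2 to compound 4 (0.29 log units; that floor lies within the scatter). Whereas compounds 1, 2 and 3, which differ only in the substituted phenyl on the amine nitrogen, lie within the scatter of one another, this change reaches beyond the scatter against compound 1 and compound 3, so the position does respond to what is placed there.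

This single change removes the aromatic ring and the hydrogen-bond donor together, and the compounds shown leave open which of the two matters. A cyclohexylamino group would keep the donor on a non-aromatic ring, and a methyl(phenyl)amino group would keep the aromatic ring without the donor.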